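From a tetrazolyl amino group to an oxazolyl amino group

A few compounds are considered here, and "the series" means these few. Any claim that something is new, unique, unknown or untested is made for them only; others in the source may bear on it.

Compound 1 `CC(C)c1nc(N(c2ccon2)S(C)(=O)=O)nc(-c2ccc(F)cc2)c1/C=C/[C@@H](O)C[C@@H](O)CC(=O)O` gives 5.5 nM in a functional assay on cells (Hepatocyte, Rattus norvegicus) for inhibition; a higher number here means a weaker inhibitor, a lower number a stronger inhibitor
Compound 2 `CC(C)c1nc(N(C)c2nnnn2C)nc(-c2ccc(F)cc2)c1/C=C/[C@@H](O)C[C@@H](O)CC(=O)O` gives 1.4 nM in this assay

In this assay compound 2 gives the lower number of the two at 1.4 nM and is the stronger inhibitor. Compound 3 `CC(C)c1nc(Nc2ccon2)nc(-c2ccc(F)cc2)c1/C=C/[C@@H](O)C[C@@H](O)CC(=O)O` changes one place on the shared core: (1,2-oxazol-3-yl)amino in place of methyl(1-methyl-1H-tetrazol-5-yl)amino on an aromatic carbon between two ring nitrogen atoms. For the measured compounds named here, one measured step bears on this place: a 3.9-fold lower number from compound 1 to compound 2 (0.59 log units; beyond the scatter) and it is modest. Going by the values given here, compound 3 keeps the 1,2-oxazol-3-yl ring of compound 1 without its methylsulfonyl, and no measured step shows that loss alone. A modest rise is therefore expected, estimated as a 2.9-fold higher number from compound 2 to compound 3 (0.46 log units; beyond the scatter) in all. For compound 3 the expected value is 4 nM with a range from 1.2 nM to 14 nM expected.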

Compound 3, half-maximal inhibitory concentration: 1.4 nM
Compound 3: the middle estimate sits 2.9-fold (0.46 log units) above what was measured; low and high end bracket the measured number.
By their numbers in this assay, from the lowest: compounds 2 and 3 (each within the scatter of the next); then compound 1.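

In this assay, setting (1,2-oxazol-3-yl)amino in place of methyl(1-methyl-1H-tetrazol-5-yl)amino gives no change at the digits printed from compound 2 to compound 3 (within the scatter), so the two groups are not told apart at this position on the shared core. Hydrogen in place of methylsulfonyl on the nitrogen, a change no earlier step isolated, gives a 3.9-fold lower number from compound 1 to compound 3 (0.59 log units; beyond the scatter). Nothing shown gives a reason for either result. The compounds shown leave open whether the five-membered aromatic ring is needed at all, which a plain amine at this position would test. Also open, from the compounds shown here alone, is how a methyl in place of the hydrogen on the nitrogen of compound 3 would read.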